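Removing the ring-nitrogen substituent from compound 3

A few compounds are considered here, and "the series" means these few. Any claim that something is new, unique, unknown or untested is made for them only; others in the source may bear on it.

Of the compounds shown here, three sharing one core have been measured in a functional assay on CHO cells for antagonist activity at C-X-C chemokine receptor type 3 (Homo sapiens), read by GTPgammaS binding, with a stated time of 30 min; on this read-out higher numbers stand for weaker inhibition and lower numbers for stronger inhibition. Compound 1 `O=C(N1CCCC(c2ccccc2)(C2CCN(Cc3ccc(Br)cc3)CC2)C1)C(F)(F)F` gives 690 nM, compound 2 `CCC(=O)N1CCCC(c2ccccc2)(C2CCN(Cc3ccc(Br)cc3)CC2)C1` gives 290 nM, and compound 3 `O=C1CC1N1CCCC(c2ccccc2)(C2CCN(Cc3ccc(Br)cc3)CC2)C1` gives 180 nM. Compound 3 therefore has the lowest number of the three, though its separation from compound 2 is only a 1.6-fold lower number from compound 2 to compound 3 (0.21 log units; within the scatter), which is within the scatter, whereas the move a 3.8-fold lower number from compound 1 to compound 3 (0.58 log units; beyond the scatter) lies beyond it.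

Compound 4 `Brc1ccc(CN2CCC(C3(c4ccccc4)CCCNC3)CC2)cc1` differs from compound 3 in one place: hydrogen in place of 2-oxocyclopropyl on an amine nitrogen in a ring. For the measured compounds named here, no measured step removes a group from this nitrogen outright; the steps seen so far only exchange one substituent for another, as in a 2.4-fold lower number from compound 1 to compound 2 (0.38 log units; beyond the scatter) and a 3.8-fold lower number from compound 1 to compound 3 (0.58 log units; beyond the scatter), both modest. Those exchanges show that this assay tolerates different groups on the ring nitrogen with only modest shifts, but they say nothing about a bare hydrogen there. The expected step of a 2.2-fold higher number from compound 3 to compound 4 (0.35 log units; beyond the scatter) is therefore uncertain in direction, and a modest weakening is taken as the central guess, with room for either outcome. Compound 4 is estimated at 400 nM, with a range from 120 nM to 1500 nM.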

Compound 4, half-maximal inhibitory concentration: > 10000 nM
Compound 4: no number, only a limit; the forecaster's own chance of this, stated with the estimate: 5%; middle value at least 25-fold (1.39 log units) away from the limit.
By their numbers in this assay, from the lowest: compounds 3 and 2 (each within the scatter of the next); then compound 1. At a limit, above all of these: compound 4.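

The value of compound 4 in this assay is a limit of the assay and not a number: the limit of > 10000 nM in this assay, at which 1 of the 4 values shown sits.

Exchanging one group for another on this amine nitrogen in a ring had shifted the number only modestly, but hydrogen in place of each of the three groups gives a large step every time: an at least 55-fold higher number from compound 3 to compound 4 (1.74 log units; beyond the scatter), an at least 34-fold higher number from compound 2 to compound 4 (1.53 log units; beyond the scatter) and an at least 14-fold higher number from compound 1 to compound 4 (1.16 log units; beyond the scatter). Among these four compounds, then, the three that carry a carbonyl-bearing group on this nitrogen all give a measured number, and the one with a bare hydrogen there gives only a limit, so this position is far less forgiving than the earlier exchanges suggested.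

The compounds shown leave open whether it is the carbonyl or simply the presence of a group that matters, since every substituted compound here carries a carbonyl, and a plain methyl or benzyl group on this nitrogen would separate the two. They also leave open how a longer acyl chain or a sulfonyl group would behave at this position.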